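Swapping an Aryl Group for Carboxy: A Stability Forecast

A few compounds are considered here, and "the series" means these few. Any claim that something is new, unique, unknown or untested is made for them only; others in the source may bear on it.

Compounds measured in an ADME assay on S9 fraction from liver (Rattus norvegicus) for metabolic stability, read by LC-MS, using NADPH, with a stated time of 30 min; a lower number here means that less of the compound is left, a higher number that more of the compound is left:
- Compound 1 `CCCCCCCCc1ccc(OCC(=O)Cn2nnc(SC)n2)cc1`: < 5%, a limit of the assay and not a number
- Compound 2 `CCCCCCCCc1ccc(OCC(=O)Cn2nnc(-c3ccccc3Cl)n2)cc1`: 28%
- Compound 3 `CCCCCCCCc1ccc(OCC(=O)Cn2nnc(-c3cccc(S(=O)(=O)N(C)C)c3)n2)cc1`: 9%

Of the two actual numbers in this assay, compound 3 holds the lower one, 9%. The measured step to it is a number 19 percentage points lower from compound 2 to compound 3 (beyond the scatter).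

Compound 4 `CCCCCCCCc1ccc(OCC(=O)Cn2nnc(C(=O)O)n2)cc1` keeps the shared core but carries carboxy in place of 3-(dimethylsulfamoyl)phenyl on an aromatic carbon. All three measured steps change this same place. Besides the step already given, they are a number at least 23 percentage points higher from compound 1 to compound 2 (beyond the scatter) and a number at least 4 percentage points higher from compound 1 to compound 3 (that floor lies within the scatter). Their sizes therefore range from one that cannot be told from the scatter to modest ones, and the one clear rise, to compound 2, comes with 2-chlorophenyl. None of the steps brings in carboxy, so they give no direction for this change. The low end of the scale also matters, with the limit of < 5% in this assay, at which 1 of the 3 values shown sits.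

The expected change is small and within the scatter, namely a number 4 percentage points higher from compound 3 to compound 4 (within the scatter). Compound 4 is estimated at 13%, with an expected range from 4% to 40%.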

Compound 4, percent of the compound remaining: 52%
For compound 4 the middle estimate is 39 percentage points below the measured one, and the stated range ends below it.
By their numbers in this assay, from the lowest: compound 3; then compound 2; then compound 4. At a limit, below all of these: compound 1.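

In this assay, carboxy on this aromatic carbon, between two ring nitrogen atoms, gives a number 43 percentage points higher from compound 3 to compound 4 (beyond the scatter), and set against 2-chlorophenyl it gives a number 24 percentage points higher from compound 2 to compound 4 (beyond the scatter). Until now the clear rise at this place had come with 2-chlorophenyl, whereas compound 4 shows that a small group with no ring can stand here and give a higher number than either compound bearing a phenyl group, so a six-membered aromatic ring at this place is not needed for the highest number shown. Against the methylsulfanyl group of compound 1, the change gives a number at least 47 percentage points higher from compound 1 to compound 4 (beyond the scatter), but that step starts from a limit of the assay and not a number: the limit of < 5% in this assay, at which 1 of the 4 values shown sits.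

With carboxy seen only once, the compounds shown leave open whether the rise belongs to that group itself or would also appear with another small group at this place, such as a methyl ester, a primary amide or a hydroxymethyl group. They also leave open whether it would persist if the octyl chain gave way to a shorter alkyl chain.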